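A few compounds are considered here, and "the series" means these few. Any claim that something is new, unique, unknown or untested is made for them only; others in the source may bear on it.

Compound 2 `C(=N/N(Cc1ccccc1)Cc1ccccc1)\c1cccs1` shares its core with compound 1 `Clc1ccc(/C=N/N(Cc2ccccc2)Cc2ccccc2)cc1Cl`; the two differ only in the aryl group attached to the carbon that carries the double bond to nitrogen. In an assay on liver (Sus scrofa) for inhibition of glucose-6-phosphatase catalytic subunit 1 (Homo sapiens), using microsomes (on this read-out lower numbers stand for stronger inhibition and higher numbers for weaker inhibition), compound 1 gives 2000 nM, and in this assay compound 2 gives 1500 nM. Compound 2 thus holds the lower of the two numbers, but the step from compound 1 to compound 2, a 1.3-fold lower number from compound 1 to compound 2 (0.12 log units; within the scatter), lies within the scatter, so no order between them can be read. Compound 3 `C(=N/N(Cc1ccccc1)Cc1ccccc1)\c1cccnc1` differs from compound 2 in one place: pyridin-3-yl in place of thiophen-2-yl on a carbon with a double bond to nitrogen. Among the compounds with values here, the only measured step that bears on this change is that aryl exchange between compound 1 and compound 2, which stayed within the scatter. On that basis compound 3 is expected to show no step beyond the scatter, an estimated change of a 1.2-fold higher number from compound 2 to compound 3 (0.08 log units; within the scatter). Compound 3 is therefore estimated at 1800 nM, within a range from 700 nM to 5000 nM.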

Compound 3, half-maximal inhibitory concentration: 3700 nM
Compound 3: middle estimate off by 2.1-fold (0.31 log units), on the low side, within the range that was stated.
By their numbers in this assay, from the lowest: compounds 2, 1 and 3 (each within the scatter of the next, the first and the last beyond it).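

At the carbon with a double bond to nitrogen, the aryl exchange now gives a step beyond the scatter: pyridin-3-yl in place of thiophen-2-yl gives a 2.5-fold higher number from compound 2 to compound 3 (0.39 log units; beyond the scatter), which is modest but shows that this position is not indifferent to the group it carries. Pyridin-3-yl in place of 3,4-dichlorophenyl gives a 1.9-fold higher number from compound 1 to compound 3 (0.27 log units; within the scatter), so compound 3 separates from compound 2 but cannot be separated from compound 1. No measurement is available that would account for the step between compound 2 and compound 3.

As far as these compounds go, whether that step follows the ring size or the ring nitrogen stays open, and an unsubstituted phenyl, furan-2-yl or pyridin-4-yl at this carbon would help to separate the two. From the compounds shown here alone, how an amine or a carboxylic acid on the aryl ring would read also remains open.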